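A few compounds are considered here, and "the series" means these few. Any claim that something is new, unique, unknown or untested is made for them only; others in the source may bear on it.

Measured compounds in the series:
compound 1 `Cc1ncnc2c1c(-c1cc3ccccc3o1)cn2[C@@H]1O[C@H](CO)[C@@H](O)[C@H]1O`, a functional assay on HCT-116 cells (Homo sapiens), read by MTT assay, with a stated time of 72 h; on this read-out higher numbers stand for weaker inhibition and lower numbers for stronger inhibition: > 20000 nM
compound 2 `Cc1ncnc2c1c(-c1ccsc1)cn2[C@@H]1O[C@H](CO)[C@@H](O)[C@H]1O`, this assay: 1430 nM

Compound 1 gives only a limit in this assay, > 20000 nM; no number stands for it, and it sits at the limit of > 20000 nM in this assay, at which 1 of the 2 values shown sits. Compound 2 gives 1430 nM in this assay. For the measured compounds named here, the one measured step, an at least 13-fold lower number from compound 1 to compound 2 (1.14 log units; beyond the scatter), concerns a different position and a different kind of change, so it does not bear on the step considered here.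

The unmeasured compound 3 `CNc1ncnc2c1c(-c1cc3ccccc3o1)cn2[C@@H]1O[C@H](CO)[C@@H](O)[C@H]1O` differs from compound 1 by methylamino in place of methyl on an aromatic carbon. Going by the values given here, no measured pair alters this position, so there is nothing to set the direction or size of the step from compound 1 to compound 3 in this assay. With compound 1 at a limit, the step of a number no higher from compound 1 to compound 3 (the limit leaves the size open) is expected, and it may well remain a limit. The estimate for compound 3 in this assay is 20000 nM, within a range of 4000 nM to 100000 nM.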

Compound 3, half-maximal inhibitory concentration: > 20000 nM
Compound 3: a limit, no number (the forecaster's own chance of this, stated with the estimate: 60%); the middle value sits exactly at the limit.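

In this assay compound 3 gives > 20000 nM, a limit and not a number. Compound 1 also stands at a limit, so no step between compound 1 and compound 3 can be read: the limit of > 20000 nM in this assay, at which 2 of the 3 values shown sit.

The compounds shown leave open what methylamino in place of methyl does in this assay alongside thiophen-3-yl, the group carried by compound 2.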